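A larger ring on the amide carbonyl of compound 1

This account rests on a few compounds, and the source may have more. Where it says the series, first, only, none or still open, it means among the compounds named here.

Compound 1 `CCn1c(-c2cnc(C)nc2)nc2c(O[C@H]3CCN(C(=O)C4CC4)C3)ncnc21` is the slowest-cleared of the three measured compounds: in an ADME assay on the whole organism (Rattus norvegicus, strain Wistar Han) for pharmacokinetics (on this read-out higher numbers stand for fast clearance and lower numbers for slow clearance), compound 1 gives 9.7 mL/min/kg. Compound 2 `CCC(=O)N1CC[C@H](Nc2ncnc3c2nc(-c2cnc(C)nc2)n3CC)C1` gives 21 mL/min/kg and compound 3 `CCn1c(-c2cnc(C)nc2)nc2c(N[C@H]3CCN(C(=O)C4CCOCC4)C3)ncnc21` gives 24 mL/min/kg, and both stand beyond the scatter above compound 1. For the measured compounds named here, the only single-point step among the measured compounds is a 1.1-fold higher number from compound 2 to compound 3 (0.06 log units; within the scatter); there, an oxygen-containing ring took the place of a small group on the carbonyl carbon without moving the number beyond the scatter.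

Compound 4 `CCn1c(-c2cnc(C)nc2)nc2c(O[C@H]3CCN(C(=O)[C@H]4C[C@@H](OC)C4)C3)ncnc21` differs from compound 1 by 3-methoxycyclobutyl in place of cyclopropyl on a carbonyl carbon. This change also sits on the carbonyl carbon and also brings in an oxygen-containing ring, so the step from compound 2 to compound 3 is the closest guide, and it was flat. Compound 4 is therefore expected to stay within the scatter of compound 1, with the expected step being a 1.2-fold higher number from compound 1 to compound 4 (0.09 log units; within the scatter), leaning slightly upward. Compound 4 is estimated at 12 mL/min/kg, within a range of 6 mL/min/kg to 24 mL/min/kg.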

Compound 4, clearance: 3.8 mL/min/kg
For compound 4 the middle estimate is 3.2-fold (0.50 log units) above the measured one; the whole stated range lies above it.
By their numbers in this assay, from the lowest: compound 4; then compound 1; then compounds 2 and 3 (each within the scatter of the next).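

In this assay, the group on the carbonyl carbon turns out to be able to move the number: the change from cyclopropyl to 3-methoxycyclobutyl gives the step (a 2.6-fold lower number from compound 1 to compound 4 (0.41 log units; beyond the scatter)), whereas the earlier step at this place (a 1.1-fold higher number from compound 2 to compound 3 (0.06 log units; within the scatter)) stayed within the scatter. That earlier step belongs to a different pair with a different oxygen-containing ring, so a flat result there did not carry over to this change, and the larger group here goes with slower clearance, not faster. No available measurement gives a reason for this step.

As far as these compounds go, it remains open whether the step follows the four-membered ring or the methoxy group, which a plain cyclobutyl or a 3-hydroxycyclobutyl on the same carbonyl carbon could separate. From the compounds shown here alone, the effect of the other arrangement of the two defined stereocentres also stays open.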